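This account rests on a few compounds, and the source may have more. Where it says the series, first, only, none or still open, it means among the compounds named here.

Measured so far:
- compound 1 `CSc1cc(C)nc(NC(=S)NC(=O)c2c(-c3ccc(Cl)cc3Cl)noc2C)n1`: 86.1%
- compound 2 `Cc1cc(Cl)nc(NC(=S)NC(=O)c2c(-c3ccc(Cl)cc3Cl)noc2C)n1`: 48.3%
- compound 3 `COc1cc(Cl)nc2n/c(=N/C(=O)c3c(-c4ccc(Cl)cc4Cl)noc3C)sn12`: 65.9%

All three were tested in a functional assay on the whole organism for inhibition, with Chenopodium ficifolium as the target, with a stated time of 72 h, tested at 100 mg/L; on this read-out higher numbers stand for more inhibition of growth at the one concentration tested and lower numbers for less inhibition of growth. Compound 1 gives 86.1%, compound 2 gives 48.3%, and compound 3 gives 65.9%.

Compound 1 and compound 2 differ in one place only, (methylsulfanyl in place of chloro on an aromatic carbon). In this assay that change gave a number 37.8 percentage points higher from compound 2 to compound 1 (beyond the scatter).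

Compound 4 `COc1cc(SC)nc2n/c(=N/C(=O)c3c(-c4ccc(Cl)cc4Cl)noc3C)sn12` is not yet measured. It differs from compound 3 in the same way, (methylsulfanyl in place of chloro on an aromatic carbon). The surroundings are not identical: in compound 3 the carbon that carries the chloro is part of a fused or bridged system of two rings, meta to a fused ring, meta to a methoxy group and para to a fused ring, whereas in compound 2 it is meta to a large group and meta to a methyl group. The two cores of compound 2 and compound 3 also differ in a way that is not broken down here. So the change from compound 3 to compound 4 is the same kind of change as that from compound 2 to compound 1, not the same change.

Among the compounds with values here, because the single comparable step gave a number 37.8 percentage points higher from compound 2 to compound 1 (beyond the scatter), compound 4 is expected to show more inhibition than compound 3, with an estimated step of a number 19.1 percentage points higher from compound 3 to compound 4 (beyond the scatter). This rests on one pair only. Compound 4 is therefore estimated at 85%, most likely between 65% and 98%.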

Compound 4, percent growth inhibition at one concentration: 68.3%
Beside the measured number, compound 4's estimate is 16.7 percentage points above it, within the range that was stated.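

In this assay, within the data shown here, putting methylsulfanyl in place of chloro on the core of compound 3 gave a number 2.4 percentage points higher from compound 3 to compound 4 (within the scatter), so on this core the swap produced no step that can be told apart from the usual spread of repeated measurements. Among these compounds, the same swap on the core of compound 2 gave a number 37.8 percentage points higher from compound 2 to compound 1 (beyond the scatter), and the two results do not agree in size: the same change on two cores in this assay, a number 37.8 percentage points higher (beyond the scatter) from compound 2 to compound 1 and a number 2.4 percentage points higher (within the scatter) from compound 3 to compound 4, 35.4 percentage points apart, beyond the scatter of two such steps This shows that a large gain seen with this change on one core cannot simply be expected on another core, but with only two pairs it does not show which feature of the two cores sets them apart, or how the change would behave on any further core.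

The compounds shown leave open what other groups would do at this aromatic carbon, for example an amine or a longer chain such as ethylsulfanyl, and whether either would give a large step on one core and almost none on the other. They also leave open how these compounds compare at other concentrations, as each number here comes from a single tested concentration in a single plant species.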